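Adding a Chloro Group to the Core of Compound 1

This account rests on a few compounds, and the source may have more. Where it says the series, first, only, none or still open, it means among the compounds named here.

Measured compounds:
compound 1, `CC(C)(C)OC(=O)/C=C1/C(=O)Nc2ccccc21`: 94.5%
compound 2, `CN1C(=O)/C(=C/C(=O)OC(C)(C)C)c2ccccc21`: 94.7%
compound 3, `CC(C)(C)OC(=O)/C=C1/C(=O)Nc2ccc(OC(F)(F)F)cc21`: 95.9%

In a functional assay on HL-60 cells (Homo sapiens) for inhibition, read by CCK-8 assay, with a stated time of 72 h, tested at 20 uM (a higher number here means more inhibition of growth at the concentration tested, a lower number less inhibition of growth), compound 1 gives 94.5%. Compound 2 and compound 3 both lie within the usual scatter of compound 1, so the three numbers cannot be told apart. Compound 4, `CC(C)(C)OC(=O)/C=C1/C(=O)Nc2c(Cl)cccc21`, differs from compound 1 by chloro in place of hydrogen on an aromatic carbon. For the measured compounds named here, two measured steps bear on this change, each altering the shared core at one place: a number 0.2 percentage points higher from compound 1 to compound 2 (within the scatter) and a number 1.4 percentage points higher from compound 1 to compound 3 (within the scatter). Neither moved the number beyond the scatter, and the third substitution is of the same small kind, so no step beyond the scatter is expected: no change at the digits printed from compound 1 to compound 4 (within the scatter) is the estimate. Compound 4 is therefore expected to give 94.5%, with a range from 86% to 99%.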

Compound 4, percent growth inhibition at one concentration: 93.7%
Compound 4: the middle estimate sits 0.8 percentage points above what was measured; the measured number falls inside the stated range.
By their numbers in this assay, from the lowest: compounds 4, 1, 2 and 3 (each within the scatter of the next).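

Chloro in place of hydrogen on an aromatic carbon, ortho to a fused ring, gives a number 0.8 percentage points lower from compound 1 to compound 4 (within the scatter) in this assay and so extends the picture to a third place on the shared core, where a single chlorine also leaves the number within the scatter of compound 1. No measurement shown offers a reason for this result. On these data alone, what stays open is whether a different group on this same carbon, such as an amine or a carboxylic acid, would move the number beyond the scatter.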